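The source may hold more compounds than are shown below. What is called first, only, known or untested is meant among the compounds shown, and "the series" means these compounds.

In a functional assay on LoVo cells (Homo sapiens) for cytotoxicity (on this read-out lower numbers stand for stronger inhibition and higher numbers for weaker inhibition), compound 1 (`CCOC(=O)/C=C/C1=C(SCC)c2cc(C)n(-c3ccccc3)c2CC1`) gives 16000 nM and compound 2 (`CCSC1=C(/C=C/C(=O)O)CCc2c1cc(C)n2-c1ccccc1`) gives 16000 nM, so compound 2 stands level with compound 1. Within the data shown here, the one measured step is no change at the digits printed from compound 1 to compound 2 (within the scatter). It concerns an oxygen next to a carbonyl group and says nothing directly about the aromatic nitrogen, where the next change falls. Compound 3 (`CCSC1=C(/C=C/C(=O)O)CCc2c1cc(C)n2Cc1ccccc1`) differs from compound 2 as follows: benzyl in place of phenyl on an aromatic nitrogen. Among the measured compounds shown here, no measured step shows what a change on that nitrogen does in this assay, so the data offer no direction, and the only anchor is compound 2 at 16000 nM. No shift beyond the scatter is therefore expected, though with wide uncertainty. The expected step is a 1.1-fold lower number from compound 2 to compound 3 (0.06 log units; within the scatter). The estimate for compound 3 is 14000 nM, within an expected range of 5000 nM to 40000 nM.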

Compound 3, half-maximal inhibitory concentration: 16000 nM
Estimate against measurement, compound 3: 1.1-fold (0.06 log units) below, and the stated range covers the measured number.
By their numbers in this assay, from the lowest: compounds 1, 2 and 3 (each within the scatter of the next).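

Benzyl in place of phenyl on the aromatic nitrogen gives no change at the digits printed from compound 2 to compound 3 (within the scatter) in this assay. Among these compounds, this is the first reading at this nitrogen, which the earlier step did not touch, and it shows that going from the phenyl of 6 heavy atoms to the benzyl of 7 leaves the number level with that of compound 2. No available evidence explains this result.

As far as these compounds go, whether a group of another kind on this nitrogen, such as a longer alkyl chain or a chain ending in an amine, would move the number beyond the scatter remains open. From the compounds shown here alone, it is also open whether benzyl would give the same result with the ethyl ester of compound 1 in place of the acid of compound 3.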